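Chloro in Place of Cyano: From Compound 2 to Compound 3

The source may hold more compounds than are shown below. What is called first, only, known or untested is meant among the compounds shown, and "the series" means these compounds.

Two compounds carry numbers in an ADME assay on cells for inhibition of cytochrome P450 11B1, mitochondrial (Homo sapiens), read by HTRF; a higher number here means a weaker inhibitor, a lower number a stronger inhibitor. Compound 1 `O=C1c2ccc(Cl)cc2C(C2CC2)N1c1cccnc1` gives 32500 nM in this assay. Compound 2 `N#Cc1ccc2c(c1)CN(c1cccnc1)C2=O` gives 15500 nM in this assay, the lowest of the two numbers; its nearest neighbour is compound 1, and the gap between them lies beyond the scatter. Compound 3 `O=C1c2ccc(Cl)cc2CN1c1cccnc1` has not yet been measured in this assay. Compound 3 differs from compound 2 by chloro in place of cyano on an aromatic carbon. Among the compounds with values here, no step between two measured compounds isolates this change, since compound 1 differs from compound 2 in more than one place. Because compound 1 gives 32500 nM while also bearing a chloro, a modest rise in number is expected from compound 2 to compound 3, a 1.6-fold higher number from compound 2 to compound 3 (0.21 log units; within the scatter), though the step may not exceed the scatter. Compound 3 is estimated at 25000 nM, within a range of 10000 nM to 60000 nM.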

Compound 3, half-maximal inhibitory concentration in the cytochrome P450 11B1, mitochondrial assay: 10700 nM
Compound 3: middle estimate off by 2.3-fold (0.37 log units), on the high side, within the range that was stated.
By their numbers in the cytochrome P450 11B1, mitochondrial assay, from the lowest: compounds 3 and 2 (each within the scatter of the next); then compound 1.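

In the cytochrome P450 11B1, mitochondrial assay, the step for chloro in place of cyano on this aromatic carbon is a 1.4-fold lower number from compound 2 to compound 3 (0.16 log units; within the scatter), so the two groups cannot be told apart here. In a physicochemical assay for lipophilicity, measured as octanol-water partition (a lower number here means a more polar compound, a higher number a more lipophilic compound), compound 2 gives 1.35 and compound 3 gives 2.52, so the same change makes the compound more lipophilic while the inhibition number stays within the scatter: the measured distribution coefficient of compound 2, 1.35, and of compound 3, 2.52, a number 1.17 log units higher (beyond the scatter) With the chloro held in place, the cytochrome P450 11B1, mitochondrial assay shows a clearer step at the saturated ring carbon, where hydrogen in place of cyclopropyl gives a 3.0-fold lower number from compound 1 to compound 3 (0.48 log units; beyond the scatter).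

The compounds shown leave open whether an amine or a methoxy group on the same aromatic carbon would move the number in the cytochrome P450 11B1, mitochondrial assay beyond the scatter. They also leave open how a methyl group or a longer chain on the saturated ring carbon would compare with hydrogen and cyclopropyl.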